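Swapping ethyl for 4-hydroxyphenyl on compound 1

The source may hold more compounds than are shown below. What is called first, only, known or untested is meant among the compounds shown, and "the series" means these compounds.

In a functional assay on ECa-109 cells (Homo sapiens) for cytotoxicity, read by MTT assay, with a stated time of 72 h (on this read-out higher numbers stand for weaker inhibition and lower numbers for stronger inhibition), compound 1 `CCC(C)=C1C(=O)N(c2ccc(Cl)cc2)N(c2ccc(Cl)cc2)C1=O` gives 41100 nM, the highest of the three numbers measured. Compound 2 `O=C1C(=Cc2ccc(Br)cc2)C(=O)N(c2ccc(Cl)cc2)N1c1ccc(Cl)cc1` gives 12300 nM and compound 3 `COc1cc(C=C2C(=O)N(c3ccc(Cl)cc3)N(c3ccc(Cl)cc3)C2=O)ccc1O` gives 7100 nM. Both carry a substituted phenyl on the double-bonded chain carbon, and exchanging 4-bromophenyl for 4-hydroxy-3-methoxyphenyl gives a 1.7-fold lower number from compound 2 to compound 3 (0.24 log units; within the scatter). Compound 4 `CC(=C1C(=O)N(c2ccc(Cl)cc2)N(c2ccc(Cl)cc2)C1=O)c1ccc(O)cc1` has 4-hydroxyphenyl in place of ethyl on a double-bonded chain carbon bound to a double-bonded ring carbon and a saturated chain carbon. Among the compounds with values here, no measured step covers this exchange directly, so the expectation leans on the values of compound 2 and compound 3. The expected step is a 4.1-fold lower number from compound 1 to compound 4 (0.61 log units; beyond the scatter). For compound 4 the estimate is 10000 nM, with an expected range of 4000 nM to 25000 nM.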

Compound 4, half-maximal inhibitory concentration: 55600 nM
Estimate against measurement, compound 4: 5.6-fold (0.75 log units) below; the whole stated range lies below it.
By their numbers in this assay, from the lowest: compounds 3 and 2 (each within the scatter of the next); then compounds 1 and 4 (each within the scatter of the next).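

Exchanging ethyl for 4-hydroxyphenyl on a double-bonded chain carbon bound to a double-bonded ring carbon and a saturated chain carbon leaves this assay within the scatter, with a 1.4-fold higher number from compound 1 to compound 4 (0.13 log units; within the scatter). The earlier compounds shown here did not show that a substituted phenyl at this place can leave the number as high as ethyl does. Nothing available explains this result. Still open, as far as these compounds go, is whether a longer chain in place of ethyl, or an amine or a carboxylic acid on the phenyl ring, would shift the number.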